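The compounds below may be only part of what the source reports. "The series", "measured", "known", "first", "only" and "open" are said of these compounds alone.

Measured so far:
- compound 1, `CCC(O)c1cn(CCNc2nonc2/C(=N/O)Nc2ccc(F)c(Br)c2)nn1`: 73 nM
- compound 2, `CCC(C)(O)c1cn(CCNc2nonc2/C(=N/O)Nc2ccc(F)c(Br)c2)nn1`: 53 nM
- compound 3, `OCCOCc1cn(CCNc2nonc2/C(=N/O)Nc2ccc(F)c(Br)c2)nn1`: 28 nM

All three were run in an assay on isolated protein for inhibition of Indoleamine 2,3-dioxygenase 1 (Homo sapiens); on this read-out lower numbers stand for stronger inhibition and higher numbers for weaker inhibition. Compound 1 and compound 2 share one core and differ only by methyl in place of hydrogen on a saturated chain carbon bound to an aromatic carbon, an oxygen on a saturated carbon and a saturated chain carbon; that change gave a 1.4-fold lower number from compound 1 to compound 2 (0.14 log units; within the scatter). Compound 3 carries a different substituent on the triazole, and its core differs from that of compound 1 by (2-hydroxyethoxy)methyl in place of 1-hydroxypropyl on an aromatic carbon, which produced a 2.6-fold lower number from compound 1 to compound 3 (0.42 log units; beyond the scatter). Between compound 2 and compound 3 the step is a 1.9-fold lower number from compound 2 to compound 3 (0.28 log units; within the scatter). Compound 3 has the lowest number of the three, but only its gap to compound 1 lies beyond the scatter.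

Compound 4, `CC(OCCO)c1cn(CCNc2nonc2/C(=N/O)Nc2ccc(F)c(Br)c2)nn1`, has not yet been measured. It differs from compound 3 by methyl in place of hydrogen on a saturated chain carbon bound to an aromatic carbon and an oxygen on a saturated carbon. Among the compounds with values here, this is the same kind of change as the one from compound 1 to compound 2, not the same: there the carbon that takes the methyl is bound to an aromatic carbon, an oxygen on a saturated carbon and a saturated chain carbon, whereas here it is bound to an aromatic carbon and an oxygen on a saturated carbon. Since compound 1 to compound 2 gave only a 1.4-fold lower number from compound 1 to compound 2 (0.14 log units; within the scatter), a step of similar, small size is expected here, resting on that single precedent and on the value of compound 3, 28 nM. For compound 4 the expected step is a 1.2-fold lower number from compound 3 to compound 4 (0.07 log units; within the scatter). Compound 4 is therefore estimated at 24 nM, with a likely range from 11 nM to 55 nM.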

Compound 4, half-maximal inhibitory concentration: 134 nM
The estimate for compound 4 lay 5.6-fold (0.75 log units) below the measured number, outside the stated range (above it).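

In this assay, methyl in place of hydrogen on a saturated chain carbon bound to an aromatic carbon and an oxygen on a saturated carbon gave a 4.8-fold higher number from compound 3 to compound 4 (0.68 log units; beyond the scatter), and set beside the earlier methyl step, the change did not carry over from one core to the other: the same change on two cores in this assay, a 1.4-fold lower number (0.14 log units; within the scatter) from compound 1 to compound 2 and a 4.8-fold higher number (0.68 log units; beyond the scatter) from compound 3 to compound 4, 6.6-fold (0.82 log units) apart, beyond the scatter of two such steps

The 1-(2-hydroxyethoxy)ethyl group of compound 4 also gives a 2.5-fold higher number from compound 2 to compound 4 (0.40 log units; beyond the scatter), while a 1.8-fold higher number from compound 1 to compound 4 (0.26 log units; within the scatter) leaves compound 4 and compound 1 unseparated. This is one pair set against one pair, so it shows that a small step on one core is a poor guide to the step on the other here, but it gives no general rule for the series and does not show which difference between the two cores matters, since the carbon taking the methyl also bears a saturated chain carbon in compound 1 and not in compound 3.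

The compounds shown leave open whether the same methyl step would be large or small on a third core, for example one with an amine in place of the hydroxyl of the 2-hydroxyethoxy chain. As far as these compounds go, how a longer chain in place of 1-(2-hydroxyethoxy)ethyl would read in this assay also stays open.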